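Ethyl to Acetyl in a Level Series

This account rests on a few compounds, and the source may have more. Where it says the series, first, only, none or still open, it means among the compounds named here.

Measured in a functional assay (Nicotiana tabacum); a higher number here means a weaker inhibitor, a lower number a stronger inhibitor:
compound 1 `CSc1nc(NC2CCCCC2)c2cccnc2n1` gives 5650 nM
compound 2 `CSc1nc(Nc2ccc(Br)cc2)c2cccnc2n1` gives 5750 nM
compound 3 `CCc1ccc(Nc2nc(SC)nc3ncccc23)cc1` gives 7150 nM

The three measured compounds sit close together in this assay, and compound 3 at 7150 nM lies within the scatter of both others. The next compound, compound 4 `CSc1nc(Nc2ccc(C(C)=O)cc2)c2cccnc2n1`, has yet to be measured. It carries acetyl in place of ethyl on an aromatic carbon, para to a large group: acetyl in place of ethyl on an aromatic carbon. For the measured compounds named here, only one measured step bears on this change. Ethyl in place of bromo on an aromatic carbon gave a 1.2-fold higher number from compound 2 to compound 3 (0.09 log units; within the scatter), a small step that stays within the scatter. Going by the values given here, no measured compound carries acetyl, so the data offer no direct guide to this group, and the range must stay wide. On this limited evidence, no shift beyond the scatter is expected, and the expected step is a 1.1-fold lower number from compound 3 to compound 4 (0.04 log units; within the scatter). Compound 4 is estimated at 6500 nM, with an expected range from 3000 nM to 14000 nM.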

Compound 4, half-maximal inhibitory concentration: 8960 nM
Beside the measured number, compound 4's estimate is 1.4-fold (0.14 log units) below it; measured number inside the range.
By their numbers in this assay, from the lowest: compounds 1, 2, 3 and 4 (each within the scatter of the next).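

In this assay, acetyl brings a carbonyl and a hydrogen-bond acceptor to this aromatic carbon, para to a large group, yet the result is only a 1.3-fold higher number from compound 3 to compound 4 (0.10 log units; within the scatter) and, against the bromo compound, a 1.6-fold higher number from compound 2 to compound 4 (0.19 log units; within the scatter) in the same assay. Bromo, ethyl and acetyl at this place therefore stay within the scatter of one another across compound 2, compound 3 and compound 4, and adding the oxygen of acetyl to the two carbons gives no change that can be told apart from that scatter. Nothing available here bears on why this position tolerates these three groups so evenly.

On these data alone, whether an amine or a carboxylic acid on this carbon would move the number beyond the scatter remains open. So does the effect of a longer chain here, and whether this level picture would hold with a change in the shared core.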